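Fluoro to cyano on the shared core: expected read-out

This account rests on a few compounds, and the source may have more. Where it says the series, first, only, none or still open, it means among the compounds named here.

Compound 1 `O=C(CCCc1ccc(F)cn1)N1CCc2c(Cl)c(O)c(O)c(Cl)c2C1` gives 25% in a functional assay (Homo sapiens), tested at 10 uM; on this read-out lower numbers stand for a stronger effect and higher numbers for a weaker effect at the one concentration tested. Among the three compounds measured so far it stands second highest. Its nearest neighbour is compound 3 `O=C(CCCc1ccc(C(F)(F)F)cn1)N1CCc2c(Cl)c(O)c(O)c(Cl)c2C1` with 19%; the step reads a number 6 percentage points lower from compound 1 to compound 3 (within the scatter). Its furthest is compound 2 `O=C(CCCc1ccc([N+](=O)[O-])cn1)N1CCc2c(Cl)c(O)c(O)c(Cl)c2C1` with 33%; that step reads a number 8 percentage points higher from compound 1 to compound 2 (within the scatter). Neither gap leaves the scatter, so no order of strength among these two and compound 1 can be stated. Going by the values given here, the only step beyond the scatter is a number 14 percentage points lower from compound 2 to compound 3 (beyond the scatter), a modest one.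

Compound 4 `N#Cc1ccc(CCCC(=O)N2CCc3c(Cl)c(O)c(O)c(Cl)c3C2)nc1` is not yet measured. It differs from compound 1 in a single place: cyano in place of fluoro on an aromatic carbon. Among the compounds with values here, the steps that bear on this are the two swaps at the same aromatic carbon starting from compound 1, a number 8 percentage points higher from compound 1 to compound 2 (within the scatter) and a number 6 percentage points lower from compound 1 to compound 3 (within the scatter). Both stayed within the scatter, one upward and one downward. Within the data shown here, no measured pair exchanges fluoro for cyano, so nothing further supports a direction. The expected step in this assay is therefore small, a number 2 percentage points higher from compound 1 to compound 4 (within the scatter), with no direction claimed beyond the scatter. Compound 4 is estimated at 27%, within a range from 14% to 40%.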

Compound 4, a percentage reported as activity, at one concentration (the size of the read-out at that concentration, not a potency): 34%
Compound 4: middle estimate off by 7 percentage points, on the low side; the measured number falls inside the stated range.
By their numbers in this assay, from the lowest: compounds 3, 1, 2 and 4 (each within the scatter of the next, the first and the last beyond it).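

Working notes on the aromatic carbon para to a large group, read in this assay: cyano in place of fluoro gives a number 9 percentage points higher from compound 1 to compound 4 (within the scatter), and cyano in place of nitro gives a number 1 percentage points higher from compound 2 to compound 4 (within the scatter), so compound 4 cannot be separated from either compound 1 or compound 2. The new information lies in the step of a number 15 percentage points higher from compound 3 to compound 4 (beyond the scatter), the second step beyond the scatter at this position, which sets trifluoromethyl apart from both cyano and nitro, while fluoro remains within the scatter of all three. Going by these compounds alone, the position therefore tolerates these four groups within a modest span, and the only separations seen involve compound 3; no measurement at hand offers a reason for that split.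

Still open, going by these compounds, is how this carbon responds to groups of another kind, such as an amine, a methoxy group or a carboxylic acid, or to plain hydrogen in place of fluoro. On these data alone, all four compounds also share the same chain and the same core, so whether the trifluoromethyl separation survives with a longer chain remains unknown.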